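Oral tail flick series: isobutyl for sec-butyl

The compounds below may be only part of what the source reports. "The series", "measured", "known", "first", "only" and "open" are said of these compounds alone.

Measured so far:
compound 1, `O=C(O)[C@@H]1CCCN1C(=O)CN(c1nc(Cl)nc2[nH]cnc12)C1CC1`: 23.6%
compound 2, `CC[C@H](C)[C@H](NC(=O)CN(c1ncnc2c1ncn2C1CCCCO1)C1CC1)C(=O)OCc1ccccc1`: 20.4%
compound 3, `O=C(OCc1ccccc1)[C@@H]1CCCN1C(=O)CN(c1ncnc2c1ncn2C1CCCCO1)C1CC1`: 17.5%

Three compounds have been run in a functional assay on the whole organism (Tail, strain ICR) with Mus musculus as the target, in the tail flick test, with a stated time of 120 min, at a dose of 25 umol/kg by the oral route; a lower number here means a weaker effect, a higher number a stronger effect of the compound at the dose given. Compound 1 gives 23.6%, compound 2 gives 20.4% and compound 3 gives 17.5%. Compound 2 sits between the other two on these numbers; its gap to compound 3 and its gap to compound 1 are both within the usual scatter, so the three read-outs cannot be told apart with confidence. No pair of these compounds differs in a single place, so no step from one to another can be put to a defined structural change.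

Compound 4, `CC(C)C[C@H](NC(=O)CN(c1ncnc2c1ncn2C1CCCCO1)C1CC1)C(=O)OCc1ccccc1`, has not yet been measured in this assay. It differs from compound 2 as follows: isobutyl in place of sec-butyl on a saturated chain carbon bound to an amide-type nitrogen and a carbonyl carbon. The two compounds hold the same atoms in a different arrangement, and the change is confined to this one saturated chain carbon.

Among the measured compounds shown here, with no step between measured compounds to lean on, and with all three numbers sitting close together, no change beyond the scatter is expected in either direction for compound 4; the expected step is a number 0.4 percentage points lower from compound 2 to compound 4 (within the scatter). Compound 4 is estimated at 20%, with a range from 10% to 31%.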

Compound 4, a percentage reported as activity, at one dose (the size of the read-out at that dose, not a potency): 12.8%
Beside the measured number, compound 4's estimate is 7.2 percentage points above it; measured number inside the range.
By their numbers in this assay, from the lowest: compounds 4, 3, 2 and 1 (each within the scatter of the next, the first and the last beyond it).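

Among the compounds shown here, the pair compound 2 and compound 4 is the only comparison confined to one place, and it gives the position its sole direct reading: in this assay, isobutyl in place of sec-butyl on a saturated chain carbon bound to an amide-type nitrogen and a carbonyl carbon gives a number 7.6 percentage points lower from compound 2 to compound 4 (within the scatter). With the same atoms joined differently, and with the defined stereocentre of the sec-butyl group gone, this one step shows no change in the read-out that can be told from the scatter at the dose given. No available measurement bears on the size of this step.

From the compounds shown here alone, only these two four-carbon groups can be compared at this position, so it stays open whether a methyl group, a longer chain such as n-hexyl, or a chain ending in an amine on this carbon would move the read-out beyond the scatter. Going by these compounds, it also stays open whether the same exchange would read alike with a free carboxylic acid in place of the benzyl ester, and a single dose gives no measure of potency for either compound.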